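The source may report more compounds than this note shows. Statements on the series, on what has been measured and on what is new or still open speak of the compounds shown alone.

Measured compounds in this series:

compound 1 `O=C(NC1CCN(Cc2ccc(OC3CCNCC3)c(Br)c2)CC1)c1cc2ccccc2s1` — 63 nM
compound 2 `O=C(NC1CCN(Cc2ccc(OC3CCNCC3)c(Br)c2)CC1)c1cc2cc(Br)ccc2s1` — 86 nM

In an assay on HEK293 cells for displacement of a labelled ligand from Urotensin-2 receptor (Homo sapiens), read by fluorescence, with a stated time of 90 min (on this read-out lower numbers stand for stronger inhibition and higher numbers for weaker inhibition), compound 2 gives 86 nM, the higher of the two numbers, while compound 1 gives 63 nM; the step of a 1.4-fold higher number from compound 1 to compound 2 (0.14 log units; within the scatter) lies within the scatter, so the two stand level.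

Compound 3 `CCc1ccc2sc(C(=O)NC3CCN(Cc4ccc(OC5CCNCC5)c(Br)c4)CC3)cc2c1` differs from compound 2 by ethyl in place of bromo on an aromatic carbon. Within the data shown here, the only measured step that bears on this place is the one from compound 1 to compound 2, where bromo entered on an aromatic carbon of the same ring in place of hydrogen and the number moved by a 1.4-fold higher number from compound 1 to compound 2 (0.14 log units; within the scatter). That step shows the position tolerating a substituent without a shift beyond the scatter. Among the measured compounds shown here, no measured step exchanges bromo for ethyl, so the expectation rests on this tolerance alone: the step from compound 2 to compound 3 is expected to stay within the scatter, a 1.1-fold lower number from compound 2 to compound 3 (0.03 log units; within the scatter). Compound 3 is therefore estimated at 80 nM, with a range of 40 nM to 170 nM.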

Compound 3, half-maximal inhibitory concentration: 180 nM
The estimate for compound 3 lay 2.3-fold (0.35 log units) below the measured number, and the stated range ends below it.
By their numbers in this assay, from the lowest: compounds 1 and 2 (each within the scatter of the next); then compound 3.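

In this assay this position proves less permissive than the bromo compound suggested: ethyl in place of bromo gives a 2.1-fold higher number from compound 2 to compound 3 (0.32 log units; beyond the scatter), and ethyl in place of hydrogen gives a 2.9-fold higher number from compound 1 to compound 3 (0.46 log units; beyond the scatter), both modest but beyond the scatter. Bromo in place of hydrogen stayed within the scatter, so the tolerance seen there does not extend to every substituent, and 5-ethyl-1-benzothiophen-2-yl gives weaker inhibition than 5-bromo-1-benzothiophen-2-yl. No measurement here accounts for the difference between ethyl and bromo.

Open, going by these compounds, is whether methyl, chloro, methoxy or a longer chain at this place would stand with bromo or with ethyl, and whether an amine or a carboxylic acid would be accepted there. Also open, on these data alone, is whether ethyl and bromo would keep this order on another carbon of the same ring.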